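The source may report more compounds than this note shows. Statements on the series, on what has been measured and on what is new or still open speak of the compounds shown alone.

Measured compounds in a functional assay on MCF7 cells (Homo sapiens) for cytotoxicity, read by MTT assay, with a stated time of 72 h; on this read-out lower numbers stand for stronger inhibition and higher numbers for weaker inhibition:
compound 1 `Cc1ccc(-c2ccnc(C(=O)Nc3ccc(Oc4ccnc5[nH]ccc45)cc3)c2)cc1`: > 10000 nM, a limit of the assay, not a number
compound 2 `Cc1cccc(-c2ccnc(C(=O)Nc3ccc(Oc4ccnc5[nH]ccc45)cc3)c2)c1`: 7470 nM

Compound 2 holds the only number shown in this assay, at 7470 nM. Compound 1 in this assay returns only a limit, > 10000 nM; that is the limit of > 10000 nM in this assay, at which 1 of the 2 values shown sits. Within the data shown here, the single measured step, an at least 1.3-fold lower number from compound 1 to compound 2 (0.12 log units; that floor lies within the scatter), rests on one side on that limit and so gives only a floor for the change.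

Compound 3 `Cc1cccc(-c2ccnc(C(=O)Nc3ccc(Oc4ccnc5[nH]ccc45)c(F)c3)c2)c1` differs from compound 2 by fluoro in place of hydrogen on an aromatic carbon. Among the measured compounds shown here, no measured step touches this position: the one step on record, an at least 1.3-fold lower number from compound 1 to compound 2 (0.12 log units; that floor lies within the scatter), concerns where the methyl group sits and says nothing about a fluoro entering here. With no measured guidance, the step in this assay from compound 2 to compound 3 is expected to stay within the scatter, with no direction favoured. Compound 3 is therefore expected to give about 6500 nM in this assay, estimated between 2500 nM and 16000 nM. The expected step from compound 2 to compound 3 is a 1.1-fold lower number from compound 2 to compound 3 (0.06 log units; within the scatter), and a limit rather than a number remains a real possibility.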

Compound 3, half-maximal inhibitory concentration: 9120 nM
Compound 3: middle estimate off by 1.4-fold (0.15 log units), on the low side; the measured number falls inside the stated range.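

Fluoro in place of hydrogen on an aromatic carbon of a six-membered aromatic ring of carbon only, ortho to a large group and meta to a large group, gives the first reading at this position in this assay, with a 1.2-fold higher number from compound 2 to compound 3 (0.09 log units; within the scatter). Unlike the earlier step on where the methyl group sits, which rests on a limit on one side, this step joins two numbers, so its size can be read, and at this position compound 2 and compound 3 lie within the scatter of each other. The reading still comes from the top of the measurable range, where one compound in the series gives a limit and not a number: the limit of > 10000 nM in this assay, at which 1 of the 3 values shown sits.

From the compounds shown here alone, whether chloro, methoxy or an amine at this same position would separate from compound 2 beyond the scatter stays open. Also open, going by these compounds, is whether fluoro at this position would give a comparable step with the 4-methylphenyl group of compound 1 in place of the 3-methylphenyl group.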